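Working notes on compounds 1 to 4

This account rests on a few compounds, and the source may have more. Where it says the series, first, only, none or still open, it means among the compounds named here.

Compound 1 `COc1ccccc1C[C@H]1COC(=O)[C@@H]1Cc1ccc(Cl)c(Cl)c1`, compound 2 `CCOc1ccccc1C[C@H]1COC(=O)[C@@H]1Cc1ccc(Cl)c(Cl)c1` and compound 3 `Cc1ccc(C[C@H]2COC(=O)[C@@H]2Cc2ccc(Cl)c(Cl)c2)cc1` have been measured in a functional assay on HL-60 cells (Homo sapiens) for cytotoxicity, read by WST assay, with a stated time of 48 h; on this read-out lower numbers stand for an effect already at smaller amounts and higher numbers for an effect only at larger amounts of compound; compound 4 `CCc1ccc(C[C@H]2COC(=O)[C@@H]2Cc2ccc(Cl)c(Cl)c2)cc1` has not. In this assay compound 1 gives 14000 nM, compound 2 gives 15000 nM and compound 3 gives 19000 nM. The three numbers sit close together: a 1.1-fold higher number from compound 1 to compound 2 (0.03 log units; within the scatter), and a 1.4-fold higher number from compound 1 to compound 3 (0.13 log units; within the scatter).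

The change from compound 1 to compound 2 is methyl in place of hydrogen on a saturated chain carbon bound to an oxygen on an aromatic ring. The change from compound 3 to compound 4 is methyl in place of hydrogen on a saturated chain carbon bound to an aromatic carbon. These are the same kind of change, though not the same: in the first the place is on a saturated chain carbon bound to an oxygen on an aromatic ring, in the second it is on a saturated chain carbon bound to an aromatic carbon. The two cores differ as follows: 4-methylphenyl in place of 2-methoxyphenyl on a saturated chain carbon bound to a saturated ring carbon.

Going by the values given here, the earlier step, a 1.1-fold higher number from compound 1 to compound 2 (0.03 log units; within the scatter), is the only guide to the new one. The new step in this assay is expected to be of similar small size, a 1.1-fold higher number from compound 3 to compound 4 (0.02 log units; within the scatter), resting on that single precedent and on the narrow spread of the measured numbers. For compound 4 the expected value in this assay is 20000 nM, with a range from 10000 nM to 40000 nM.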

Compound 4, half-maximal effective concentration: 16000 nM
Compound 4: the middle estimate sits 1.3-fold (0.10 log units) above what was measured; the range from low to high includes it.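

In this assay the added methyl gives a 1.2-fold lower number from compound 3 to compound 4 (0.07 log units; within the scatter), and the broader exchange of aromatic group gives a 1.1-fold higher number from compound 1 to compound 4 (0.06 log units; within the scatter). Set beside the earlier step, the same change shows no detectable difference between the two cores: the same change on two cores in this assay, a 1.1-fold higher number (0.03 log units; within the scatter) from compound 1 to compound 2 and a 1.2-fold lower number (0.07 log units; within the scatter) from compound 3 to compound 4, 1.3-fold (0.10 log units) apart, within the scatter of two such steps

On both cores, then, methyl in place of hydrogen leaves the number within the scatter, but two pairs with such small steps show neither a real effect of the change on either core nor that this would hold on other cores in the series, and the place of the change is also not identical in the two pairs.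

Still open, on these data alone, is whether a different group on the aromatic ring, such as an amine, a carboxylic acid or a chain longer than ethyl, would move the number beyond the scatter. As far as these compounds go, whether changes elsewhere on the shared core would do so also remains open.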